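Thiophene-to-furan swap in a nucleoside series

The source may hold more compounds than are shown below. What is called first, only, known or untested is meant among the compounds shown, and "the series" means these compounds.

Measured in a functional assay on K562 cells (Homo sapiens), read by MTT assay, with a stated time of 72 h; a lower number here means a stronger inhibitor, a higher number a weaker inhibitor:
- compound 1 `Cc1ncnc2c1c(-c1ccoc1)cn2[C@@H]1O[C@H](CO)[C@@H](O)[C@H]1O` gives only the assay limit > 20000 nM.
- compound 2 `CNc1ncnc2c1c(-c1ccsc1)cn2[C@@H]1O[C@H](CO)[C@@H](O)[C@H]1O` gives only the assay limit > 20000 nM.
- compound 3 `Cc1ncnc2c1c(-c1ccsc1)cn2[C@@H]1O[C@H](CO)[C@@H](O)[C@H]1O` gives 320 nM.

Among the measured compounds shown here, compound 3 is the one measured compound with a number; its two neighbours sit at the limit (the limit of > 20000 nM in this assay, at which 2 of the 3 values shown sit). The change furan-3-yl in place of thiophen-3-yl on an aromatic carbon brought an at least 62-fold higher number from compound 3 to compound 1 (1.79 log units; beyond the scatter). The change methylamino in place of methyl on an aromatic carbon describes how the cores of compound 2 and compound 3 differ, and in the other direction this gave an at least 62-fold lower number from compound 2 to compound 3 (1.79 log units; beyond the scatter).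

Compound 4 `CNc1ncnc2c1c(-c1ccoc1)cn2[C@@H]1O[C@H](CO)[C@@H](O)[C@H]1O` is not yet measured. It arises from compound 2 by furan-3-yl in place of thiophen-3-yl on an aromatic carbon, the same change, at the same place, as from compound 3 to compound 1. Because that change gave an at least 62-fold higher number from compound 3 to compound 1 (1.79 log units; beyond the scatter), and because compound 2 already sits at the limit of > 20000 nM in this assay, at which 2 of the 3 values shown sit, compound 4 is expected to remain at the limit too, so the expected step that the limit leaves unreadable from compound 2 to compound 4 is not resolvable in this assay. Compound 4 is estimated at 60000 nM, between 20000 nM and 300000 nM.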

Compound 4, half-maximal inhibitory concentration: > 20000 nM
Compound 4: no number, only a limit (the forecaster's own chance of this, stated with the estimate: 95%); the middle value lies beyond the limit too.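

In this assay compound 4 gives > 20000 nM, which is a limit and not a number. No step to compound 4 from compound 2 or compound 1 can be read, because all three compounds sit at the limit: the limit of > 20000 nM in this assay, at which 3 of the 4 values shown sit.

The compounds shown leave open how far compound 1, compound 2 and compound 4 differ from one another.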